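From carbamoyl to methoxycarbonyl at the assay limit

A few compounds are considered here, and "the series" means these few. Any claim that something is new, unique, unknown or untested is made for them only; others in the source may bear on it.

In an ADME assay on HCT-116 cells (Homo sapiens) for antiproliferative activity (on this read-out lower numbers stand for stronger inhibition and higher numbers for weaker inhibition), compound 1 `COc1ccc(C(=O)O)cc1COc1ccc(Cl)c(C)c1` gives > 50000 nM, which is a limit of the assay and not a number. Compound 2 `COc1ccc(C(N)=O)cc1COc1ccc(Cl)c(C)c1` gives > 50000 nM, and this too is a limit rather than a number. Compound 2 therefore has no exact position on the scale, and the whole record so far is the limit of > 50000 nM in this assay, at which 2 of the 2 values shown sit.

Compound 3 `COC(=O)c1ccc(OC)c(COc2ccc(Cl)c(C)c2)c1` keeps the shared core and alters one group: methoxy in place of amino on a carbonyl carbon. In words, methoxy stands in place of amino on a carbonyl carbon, so carbamoyl becomes methoxycarbonyl.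

One measured step involves this same carbonyl carbon: a step that the two limits leave unreadable from compound 1 to compound 2. It offers no size to carry over and no direction to follow. Among the measured compounds shown here, with only that step to lean on, no change beyond the usual scatter is expected, although the data cannot rule one out. The estimated change is a number no higher from compound 2 to compound 3 (the limit leaves the size open). For compound 3 the expected value is 50000 nM, with an estimated range from 15000 nM to 100000 nM.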

Compound 3, half-maximal inhibitory concentration: 23000 nM
Estimate against measurement, compound 3: 2.2-fold (0.34 log units) above; the measured number falls inside the stated range.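

The carbonyl carbon now gives a first readable result. In this assay, methoxy in place of amino at this carbon gives an at least 2.1-fold lower number from compound 2 to compound 3 (0.33 log units; beyond the scatter), and methyl in place of hydrogen on the oxygen of the same group gives an at least 2.1-fold lower number from compound 1 to compound 3 (0.33 log units; beyond the scatter). The step between compound 1 and compound 2 cannot be read, whereas these two new steps both lie beyond the scatter, with only their full size left open, so a change at this one carbon can bring the read-out down from the limit that holds the other compounds: the limit of > 50000 nM in this assay, at which 2 of the 3 values shown sit.

The compounds shown leave open how far the number can fall at this position, for instance with ethoxycarbonyl or another longer chain on the oxygen, or with a methylamino group on the carbonyl carbon. They also give no reason for the drop, and they cannot show whether the same change would lower the number on a different core.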